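Swapping methoxy for chloro in compound 1

The compounds below may be only part of what the source reports. "The series", "measured", "known", "first", "only" and "open" are said of these compounds alone.

compound 1 (`COc1ccc(N2CCN(C(=O)Cn3cnc([N+](=O)[O-])n3)CC2)cc1`): 133000 nM
compound 2 (`O=C(CN1CCN(c2ccc(C(F)(F)F)cc2)CC1)N1CCN(c2ccc(C(F)(F)F)cc2)CC1`): 31700 nM
compound 3 (`N#Cc1ccccc1N1CCN(CC(=O)N2CCN(c3ccccc3C#N)CC2)CC1`): 127000 nM

In an ADME assay on L6 cells (Rattus norvegicus) for cytotoxicity (a lower number here means a stronger inhibitor, a higher number a weaker inhibitor), compound 1 sits level with compound 3, within the usual scatter, and both have clearly higher numbers than compound 2. The next compound, compound 4 (`O=C(Cn1cnc([N+](=O)[O-])n1)N1CCN(c2ccc(Cl)cc2)CC1`), has chloro in place of methoxy on an aromatic carbon, para to a large group (chloro in place of methoxy on an aromatic carbon). Among the compounds with values here, no two measured compounds differ in only one place, so the data offer no direct guide to this change. A small step is therefore expected, leaning towards a lower number, with no change beyond the scatter as the likeliest outcome. The estimated step is a 1.4-fold lower number from compound 1 to compound 4 (0.15 log units; within the scatter) and no larger move is assumed. Compound 4 is expected at 95000 nM (range 35000 nM to 200000 nM).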

Compound 4, half-maximal inhibitory concentration: > 285000 nM
Compound 4: a limit, no number; the forecaster's own chance of this, stated with the estimate: 15%; at least 3.0-fold (0.47 log units) between middle value and limit.
By their numbers in this assay, from the lowest: compound 2; then compounds 3 and 1 (each within the scatter of the next). At a limit, above all of these: compound 4.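

Swapping methoxy for chloro on this aromatic carbon, para to a large group, gives in this assay an at least 2.1-fold higher number from compound 1 to compound 4 (0.33 log units; beyond the scatter), the only single-place step shown, so a small change here can move the number beyond the scatter. Compound 4 gives a limit rather than a number: the limit of > 285000 nM in this assay, at which 1 of the 4 values shown sits. The direction of the step and its smallest size are therefore known, but its true size is not.

From the compounds shown here alone, whether an amine, a carboxylic acid or a longer chain at this position would shift the number the same way remains open. So does whether this swap acts alike on another core.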